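The source may report more compounds than this note shows. Statements on the series, on what has been measured and on what is new or still open speak of the compounds shown alone.

Working notes on the series. Compound 1 `CC(=O)c1cc(C(=O)N[C@H](C)Cn2ccc(-c3cc(F)c(C#N)c(Cl)c3)n2)n[nH]1` and compound 2 `C[C@@H](Cn1ccc(-c2ccc(C#N)c(Cl)c2)n1)NC(=O)c1ccccc1` share the chiral propyl-linked pyrazole and chlorobenzonitrile core and differ in the amide acyl part and in the fluorine on the aryl ring. In a functional assay on LNCaP cells (Homo sapiens) for antiproliferative activity, read by CCK-8 assay, with a stated time of 6 days (a higher number here means a weaker inhibitor, a lower number a stronger inhibitor), compound 1 gives 1080 nM, and compound 2 gives 1830 nM. Compound 2 stands beside compound 1 on these two numbers, the gap between them falling within the usual scatter, so no order can be read from them.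

Compound 3 `CC(=O)c1ccc(C(=O)N[C@@H](C)Cn2ccc(-c3ccc(C#N)c(Cl)c3)n2)cc1` is reached from compound 2 by acetyl in place of hydrogen on an aromatic carbon. Among the compounds with values here, no measured pair in the set isolates this change. The added group is counted as carrying one hydrogen-bond acceptor and no donor. The step from compound 2 to compound 3 in this assay is expected to be small, at most a modest move toward a lower number and possibly none beyond the scatter, as the estimated 1.5-fold lower number from compound 2 to compound 3 (0.18 log units; within the scatter) indicates. For compound 3 the expected value in this assay is 1200 nM, with a range from 500 nM to 3000 nM.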

Compound 3, half-maximal inhibitory concentration: 3600 nM
Beside the measured number, compound 3's estimate is 3.0-fold (0.48 log units) below it; the measured number lies above the stated range.
By their numbers in this assay, from the lowest: compounds 1, 2 and 3 (each within the scatter of the next, the first and the last beyond it).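

Within the data shown here, compound 3 adds the first comparison that differs in one place only: in this assay, phenyl to 4-acetylphenyl gives a 2.0-fold higher number from compound 2 to compound 3 (0.29 log units; within the scatter), with the acetyl on an aromatic carbon para to a large group. That step lies within the scatter, so on these numbers acetyl and hydrogen at this position cannot be told apart, and the one hydrogen-bond acceptor that the acetyl adds brings no readable difference. No measurement at hand offers an explanation for this result.

From the compounds shown here alone, it remains open whether an amine or a carboxylic acid at the same position would give a step beyond the scatter. Going by these compounds, it also remains open whether the acetyl step would read the same on an aryl ring carrying the fluorine of compound 1.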